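One Ring Substituent Exchanged for Another

The source may hold more compounds than are shown below. What is called first, only, known or untested is meant among the compounds shown, and "the series" means these compounds.

Two compounds share one core. In an assay on CHO cells for antagonist activity at transient receptor potential cation channel subfamily V member 1 (Homo sapiens), read by FLIPR (a lower number here means a stronger inhibitor, a higher number a weaker inhibitor), compound 2 `CC1CCN(c2nc(C(F)(F)F)ccc2CNC(=O)C(C)(C)c2ccc(NS(C)(=O)=O)c(F)c2)CC1` gives 49 nM. Compound 1 `CC1CCN(c2nc(C(F)(F)F)ccc2CNC(=O)C(Cc2ccccc2)c2ccc(NS(C)(=O)=O)c(F)c2)CC1`, which differs from it in several places, gives 65.9 nM in this assay; the two numbers lie within the usual scatter of each other, so neither stands apart. Compound 3 `CC(C)(C(=O)NCc1ccc(C(F)(F)F)nc1SC1CCCCC1)c1ccc(NS(C)(=O)=O)c(F)c1` has not yet been measured. It differs from compound 2 by cyclohexylsulfanyl in place of 4-methylpiperidin-1-yl on an aromatic carbon. Among the compounds with values here, no measured pair shows this exchange, and the leaving and entering groups match in what is counted, so only a small step is expected, roughly a 1.4-fold higher number from compound 2 to compound 3 (0.15 log units; within the scatter), within or just beyond the scatter. Compound 3 is therefore estimated at 70 nM, between 25 nM and 200 nM.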

Compound 3, inhibition constant: 65.7 nM
The estimate for compound 3 lay 1.1-fold (0.03 log units) above the measured number; the measured number falls inside the stated range.
By their numbers in this assay, from the lowest: compounds 2, 3 and 1 (each within the scatter of the next).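

Placing cyclohexylsulfanyl where 4-methylpiperidin-1-yl stood gives a 1.3-fold higher number from compound 2 to compound 3 (0.13 log units; within the scatter) in this assay for this aromatic carbon next to the ring nitrogen. At this position, then, a six-membered ring of carbon only, joined through sulfur, can stand in for a ring holding nitrogen with no readable change in the number. No measurement shown accounts for this. Still open, as far as these compounds go, is whether a smaller group such as methoxy, or an open chain such as hexyl, would also hold the number here.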